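The source may report more compounds than this note shows. Statements on the series, on what has been measured and on what is new or still open speak of the compounds shown alone.

Compound 1 `Brc1cc2ccccc2o1`: 140000 nM
Compound 2 `NCc1cc2ccncc2s1`: 5200 nM

In an assay on isolated protein for inhibition of cytochrome P450 2A6 (Homo sapiens), read by fluorescence, with a stated time of 10 min (on this read-out higher numbers stand for weaker inhibition and lower numbers for stronger inhibition), compound 1 gives 140000 nM, the highest of the two numbers; compound 2 gives 5200 nM, a markedly lower number, and the gap between the two lies beyond the scatter. Compound 3 `N#Cc1cc2ccccc2o1` differs from compound 1 by cyano in place of bromo on an aromatic carbon, on an aromatic carbon of the five-membered ring next to the ring oxygen. Going by the values given here, no step of this kind has been measured in this assay, so its direction is uncertain; a small step toward a lower number is expected, a 1.8-fold lower number from compound 1 to compound 3 (0.24 log units; within the scatter). Compound 3 is accordingly estimated at 80000 nM, within 20000 nM to 300000 nM.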

Compound 3, half-maximal inhibitory concentration: 52000 nM
Compound 3: the middle estimate sits 1.5-fold (0.19 log units) above what was measured; measured number inside the range.
By their numbers in this assay, from the lowest: compound 2; then compound 3; then compound 1.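

In this assay the change from bromo to cyano on an aromatic carbon of the five-membered ring gives a 2.7-fold lower number from compound 1 to compound 3 (0.43 log units; beyond the scatter) and provides the first one-place comparison among these compounds. It shows that the number responds to the group at this position, next to the ring oxygen, and that the cyano group gives the stronger inhibition of the two.

Going by these compounds, whether a carboxylic acid or a methoxy group at this position would move the number further remains open. Nothing measured here explains the size or direction of this step.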